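A few compounds are considered here, and "the series" means these few. Any claim that something is new, unique, unknown or untested is made for them only; others in the source may bear on it.

Measured so far:
- compound 1, `CCCCCCCCc1cn(C(c2ccccc2)c2cc3cc(Br)ccc3nc2OC)nn1`: 14.6%
- compound 2, `CCCCCc1cn(C(c2ccccc2)c2cc3cc(Br)ccc3nc2OC)nn1`: -2%
- compound 3, `COc1nc2ccc(Br)cc2cc1C(c1ccccc1)n1cc(-c2ccc(F)cc2)nn1`: 4.04%

In an ADME assay on HEK293 cells (Homo sapiens) for cytotoxicity, read by sulforhodamine B assay, with a stated time of 48 h, tested at 10 uM (on this read-out higher numbers stand for more inhibition at the one concentration tested (going by the name of the read-out) and lower numbers for less inhibition), compound 1 gives the highest of the three numbers; its nearest neighbour is compound 3, which in this assay gives 4.04%, and compound 2 in this assay gives -2%, both of them below it by more than the scatter.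

Compound 4, `COc1nc2ccc(Br)cc2cc1C(c1ccccc1)n1cc(C2CC2)nn1`, is not yet measured. It differs from compound 1 in one place: cyclopropyl in place of octyl on an aromatic carbon

Among the compounds with values here, two measured steps bear on this change, both starting from compound 1 and both removing or shortening the octyl group. Cutting the chain gave a number 16.6 percentage points lower from compound 1 to compound 2 (beyond the scatter), and replacing it by 4-fluorophenyl gave a number 10.6 percentage points lower from compound 1 to compound 3 (beyond the scatter). Both steps went down in this assay and both went beyond the scatter. Cyclopropyl is a small group like pentyl and 4-fluorophenyl rather than octyl, so a downward step of similar size is expected, a number 13.6 percentage points lower from compound 1 to compound 4 (beyond the scatter).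

Compound 4 is therefore expected to give 1% in this assay, with a range from -9% to 11%, because the two measured steps were a number 16.6 percentage points lower from compound 1 to compound 2 (beyond the scatter) and a number 10.6 percentage points lower from compound 1 to compound 3 (beyond the scatter).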

Compound 4, a percentage reported as inhibition, at one concentration (the size of the read-out at that concentration, not a potency): 8.22%
Estimate against measurement, compound 4: 7.2 percentage points below; low and high end bracket the measured number.
By their numbers in this assay, from the lowest: compounds 2, 3, 4 and 1 (each within the scatter of the next, the first and the last beyond it).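

In this assay, cyclopropyl in place of octyl on this aromatic carbon of the five-membered aromatic ring gives a number 6.4 percentage points lower from compound 1 to compound 4 (within the scatter) as its step, so compound 4 is not separated from compound 1, whereas the pentyl of compound 2 and the 4-fluorophenyl of compound 3 both are. Against those two neighbours the new group reads differently, with a number 4.2 percentage points higher from compound 3 to compound 4 (within the scatter) for cyclopropyl in place of 4-fluorophenyl and a number 10.2 percentage points higher from compound 2 to compound 4 (beyond the scatter) for cyclopropyl in place of pentyl. Group size alone therefore does not order these four compounds: cyclopropyl, with 3 heavy atoms against 8 for octyl, stays within the scatter of octyl, while pentyl, a shorter chain than octyl, does not.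

Open, going by these compounds, is whether an amine, a carboxylic acid or a chain longer than octyl on this carbon would shift the number beyond the scatter of compound 1 or compound 2. Nothing at hand accounts for any of these steps.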